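Methylsulfanyl in place of methyl: notes on compound 4

The compounds below may be only part of what the source reports. "The series", "measured", "known", "first", "only" and "open" are said of these compounds alone.

Compound 3 `Cc1cccc2c(=O)c(-c3nn[nH]n3)c[nH]c12` carries a methyl on the shared core. In a functional assay on the whole organism (strain Sprague-Dawley) for inhibition, with Rattus norvegicus as the target (a higher number here means that more compound is needed for the effect, a lower number that less compound is needed), compound 3 gives > 5 mg/kg, which is a limit of the assay and not a number (the limit of > 5 mg/kg in this assay, at which 1 of the 3 values shown sits). Compound 1 `O=c1c(-c2nn[nH]n2)c[nH]c2ccccc12` gives 1.25 mg/kg in this assay. Compound 2 `O=c1c(-c2nn[nH]n2)c[nH]c2c(Cl)cccc12` gives 0.078 mg/kg. The measured steps are a 16-fold lower number from compound 1 to compound 2 (1.20 log units; beyond the scatter), an at least 4.0-fold higher number from compound 1 to compound 3 (0.60 log units; beyond the scatter) and an at least 64-fold higher number from compound 2 to compound 3 (1.80 log units; beyond the scatter). Compound 4 `CSc1cccc2c(=O)c(-c3nn[nH]n3)c[nH]c12` differs from compound 3 by methylsulfanyl in place of methyl on an aromatic carbon. For the measured compounds named here, no measured step exchanges a methyl for a methylsulfanyl, and compound 3 stands only at a limit, so the direction cannot be read from the earlier compounds. For compound 4 the expected step is a number no higher from compound 3 to compound 4 (the limit leaves the size open), with no change beyond the scatter. The value of compound 4 in this assay is estimated at 5 mg/kg, in the range 1 mg/kg to 25 mg/kg.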

Compound 4, minimum effective dose: 10 mg/kg
Estimate against measurement, compound 4: 2.0-fold (0.30 log units) below; low and high end bracket the measured number.
By their numbers in this assay, from the lowest: compound 2; then compound 1; then compound 4.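

In this assay, methylsulfanyl on this aromatic carbon gives a readable number on the high side of hydrogen: the change shows an 8.0-fold higher number from compound 1 to compound 4 (0.90 log units; beyond the scatter) and, set against chloro, a 130-fold higher number from compound 2 to compound 4 (2.11 log units; beyond the scatter) in the same direction, so among the groups shown only chloro lowers the number from that of compound 1. The step between compound 3 and compound 4 cannot be read, because compound 3 stands at a limit of the assay: the limit of > 5 mg/kg in this assay, at which 1 of the 4 values shown sits.

On these data alone, whether chloro is alone in this remains open. Fluoro, bromo, methoxy or an amine on the same carbon would show how far the effect extends beyond chloro.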